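The compounds below may be only part of what the source reports. "The series", "measured", "known", "first", "only" and "open" are said of these compounds alone.

Measured compounds:
compound 1, `CC[C@@H](Nc1c(C#N)c(-c2ccc(-c3cccnc3C)cc2)nc2cnccc12)C(N)=O`: 1.9
compound 2, `CCOc1ccccc1-c1ccc(-c2nc3cnccc3c(N[C@H](CC(C)C)C(N)=O)c2C#N)cc1`: 3.4
compound 3, `CC[C@@H](Nc1c(C#N)c(-c2ccc(-c3cccc(C)c3F)cc2)nc2cnccc12)C(=O)O`: 2.1

The three compounds were characterised in a physicochemical assay for lipophilicity, read by HPLC, at pH 7.5; on this read-out higher numbers stand for higher lipophilicity and lower numbers for lower lipophilicity. Compound 1 gives 1.9, the lowest of the three numbers in this assay. The number of compound 3, 2.1, lies within the usual scatter of the number of compound 1, so the two cannot be told apart. Compound 2, at 3.4, stands clearly beyond the scatter of compound 1.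

The step under consideration leads from compound 1 to compound 4, `CC[C@@H](Nc1c(C#N)c(-c2ccc(-c3cccc(Cl)c3F)cc2)nc2cnccc12)C(N)=O`, which has not yet been measured in this assay. The two structures differ as follows:

3-chloro-2-fluorophenyl in place of 2-methylpyridin-3-yl on an aromatic carbon

For the measured compounds named here, no step between measured compounds with this single change is available, so the expectation rests on the structures alone. The group that leaves carries one hydrogen-bond acceptor; the group that enters carries none and brings a fluorine and a chlorine. On that basis compound 4 is expected to read higher than compound 1 in this assay, by a step that is estimated at a number 1.30 log units higher from compound 1 to compound 4 (beyond the scatter), well beyond the scatter. Compound 4 is therefore estimated at 3.2, with a range from 2.7 to 3.7.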

Compound 4, distribution coefficient: 3.1
For compound 4 the middle estimate is 0.10 log units above the measured one; measured number inside the range.
By their numbers in this assay, from the lowest: compounds 1 and 3 (each within the scatter of the next); then compounds 4 and 2 (each within the scatter of the next).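

In this assay, the replacement of 2-methylpyridin-3-yl by 3-chloro-2-fluorophenyl, on an aromatic carbon para to a large group, reads a number 1.20 log units higher from compound 1 to compound 4 (beyond the scatter), a large step. For the compounds shown here, the earlier compounds offered no pair differing in one place, so this is the first reading of what this position alone does to the number with the rest of the structure held constant: the read-out responds strongly to the exchange of one six-membered aromatic ring for the other. The step accompanies the loss of the ring nitrogen, with its hydrogen-bond acceptor, and the arrival of a fluorine and a chlorine, but no measurement shown accounts for its size.

The compounds shown do not divide the step among these parts, as they include neither a plain phenyl nor a phenyl carrying only the fluorine or only the chlorine at this place. As far as these compounds go, how this assay would respond to a ring bearing a dimethylamino group here, or whether the same exchange gives a similar step on a compound with a carboxylic acid in place of the primary amide, also remains open.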